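Swapping the Furan Attachment Point on a Shared Core

The source may report more compounds than this note shows. Statements on the series, on what has been measured and on what is new or still open speak of the compounds shown alone.

Compound 1, `Cc1occc1C(=O)N1CCC(NC(=O)Nc2ccc(OC(F)(F)F)cc2)CC1`: 4.3 in a physicochemical assay for lipophilicity, read by HPLC, with a stated time of 90 min, tested at 100 uM; a lower number here means a more polar compound, a higher number a more lipophilic compound
Compound 2, `CC[C@H](C)C(=O)N1CCC(NC(=O)Nc2ccc(C(F)(F)F)cn2)CC1`: 3.22 in this assay
Compound 3, `O=C(Nc1ccc(C(F)(F)F)cc1)NC1CCN(C(=O)C2CCOC2)CC1`: 3.16 in this assay

Of these three numbers, compound 1 stands highest. Among the compounds with values here, compound 2 reads lower by a margin beyond the usual scatter, and compound 3 lower again, also beyond the scatter, so compound 1 is the most lipophilic of the three measured so far.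

Compound 4, `Cc1ccoc1C(=O)N1CCC(NC(=O)Nc2ccc(OC(F)(F)F)cc2)CC1`, has not yet been measured in this assay. It differs from compound 1 in one place only: 3-methylfuran-2-yl in place of 2-methylfuran-3-yl on a carbonyl carbon. The two compounds are built from the same atoms, joined differently. Within the data shown here, no measured pair shows this kind of change, so there is nothing to draw on beyond the structures themselves. The step of no change at the digits printed from compound 1 to compound 4 (within the scatter) is expected to be small, within the scatter and in no clear direction. Compound 4 is therefore estimated at 4.3, with a range from 3.9 to 4.7.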

Compound 4, partition coefficient: 4.48
Compound 4: middle estimate off by 0.18 log units, on the low side; the range from low to high includes it.
By their numbers in this assay, from the lowest: compounds 3 and 2 (each within the scatter of the next); then compounds 1 and 4 (each within the scatter of the next).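

Placing 3-methylfuran-2-yl in place of 2-methylfuran-3-yl on a carbonyl carbon gives a number 0.18 log units higher from compound 1 to compound 4 (within the scatter) in this assay and is the first comparison here of compounds that differ in one place. On this evidence, rearranging these same atoms leaves the lipophilicity reading indistinguishable, so compound 1 and compound 4 cannot be separated by this measurement. Nothing available explains the result at the level of structure.

As far as these compounds go, whether the same swap would behave alike on another core remains open. So does the reading of a furan carrying an amine or a carboxylic acid at this carbonyl carbon.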